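A few compounds are considered here, and "the series" means these few. Any claim that something is new, unique, unknown or untested is made for them only; others in the source may bear on it.

Compound 1 `CC(C)(C)c1ccc(Oc2ccc3c(NCCCNCc4ccco4)ccnc3c2)cc1` gives 9.28 in a physicochemical assay for acid dissociation.
Compound 2 `COc1cccc(CNCCCNc2ccnc3cc(-c4ccc(C(C)(C)C)cc4)ccc23)c1O` gives 9.47.
Compound 3 `CC(C)(C)c1ccc(-c2ccc3c(NCCCNCc4ccco4)ccnc3c2)cc1` gives 9.47.

In this assay compound 2 stands level with compound 3, the two together at the top of the three numbers, while compound 1 lies within the scatter of both. Compound 4 `COc1cccc(CNCCCNc2ccnc3cc(Oc4ccc(F)cc4)ccc23)c1O` differs from compound 2 in that (4-fluorophenoxy in place of 4-(tert-butyl)phenyl on an aromatic carbon). Among the measured compounds shown here, no measured step alters this position alone; the only single-point step, no change at the digits printed from compound 2 to compound 3 (within the scatter), changes the group on the chain carbon next to the amine nitrogen and leaves the read-out unmoved, and compounds 1 and 3, which differ at the same aromatic carbon as compounds 2 and 4, show values within the scatter of each other. Compound 4 is therefore expected to move little, a number 0.12 log units lower from compound 2 to compound 4 (within the scatter), and its estimated value is 9.35, between 9 and 9.7.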

Compound 4, acid dissociation constant: 9.28
For compound 4 the middle estimate is 0.07 log units above the measured one; the range from low to high includes it.
By their numbers in this assay, from the lowest: compounds 1, 4, 2 and 3 (each within the scatter of the next).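

Among the compounds shown here, until now the only measured step lay on the chain carbon, and this is the first at the aromatic carbon: in this assay, 4-fluorophenoxy in place of 4-(tert-butyl)phenyl gives a number 0.19 log units lower from compound 2 to compound 4 (within the scatter) for this exchange. The read-out thus stays within the scatter although the entering group brings one hydrogen-bond acceptor and the leaving group none. Nothing on hand explains this result.

As far as these compounds go, whether an amine or a carboxylic acid on this aromatic carbon would also stay within the scatter remains open.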